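A few compounds are considered here, and "the series" means these few. Any claim that something is new, unique, unknown or untested is made for them only; others in the source may bear on it.

Three compounds of this series have numbers in an assay for inhibition of Indoleamine 2,3-dioxygenase 1 (Homo sapiens), read by fluorescence, with a stated time of 1 h; on this read-out higher numbers stand for weaker inhibition and lower numbers for stronger inhibition. Compound 1 `NS(=O)(=O)CC(=O)NCCSc1nonc1/C(=N/O)Nc1cccc(Cl)c1` gives 21 nM in this assay. Compound 3 `N#CCC(=O)NCCSc1nonc1/C(=N/O)Nc1ccc(F)c(C(F)F)c1` gives 180 nM. Compound 2 `COc1nonc1/C(=N/O)Nc1ccc(F)c(Br)c1` gives 230 nM, the highest of the three; its gap to compound 3 lies within the scatter, while compound 1 sits clearly lower, beyond the scatter.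

Compound 4 `CS(=O)(=O)NCCSc1nonc1/C(=N/O)Nc1ccc(F)c(Br)c1` has not been measured. It differs from compound 2 in one place: a group of 8 heavy atoms (3 carbon, 1 nitrogen, 2 oxygen, 2 sulfur; no ring) in place of a group of 2 heavy atoms (1 carbon, 1 oxygen; no ring), on an aromatic carbon. The entering group resembles the sulfur-linked chains carried on the same core by compound 1 and compound 3, yet those two compounds sit on opposite sides of the scatter relative to compound 2, so a chain at this position does not by itself settle the outcome. The step expected here, a 2.6-fold lower number from compound 2 to compound 4 (0.41 log units; beyond the scatter), points toward a lower number, because compound 1 carries such a chain and gives 21 nM. The number for compound 4 is estimated at 90 nM, with a range from 30 nM to 300 nM.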

Compound 4, half-maximal inhibitory concentration: 270 nM
Compound 4: the middle estimate sits 3.0-fold (0.48 log units) below what was measured, within the range that was stated.
By their numbers in this assay, from the lowest: compound 1; then compounds 3, 2 and 4 (each within the scatter of the next).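

In this assay, the group of 8 heavy atoms in place of methoxy on the aromatic carbon gives a 1.2-fold higher number from compound 2 to compound 4 (0.07 log units; within the scatter). This one-place pair therefore shows that, with the rest of compound 2 held fixed, the much larger sulfur-linked chain and methoxy cannot be told apart at this position. No measurement on hand accounts for this result.

No one-place pair shown separates the contribution of the end of the chain from that of the substituents on the aromatic ring outside the shared core, so what sets the value of compound 1 stays open. Also open, on these data alone, is whether a primary amine, a carboxylic acid or a longer chain at this position would leave the number within the scatter of compound 2.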